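Unmasking a Capped Amine on a Cell-Growth Inhibitor

The source may hold more compounds than are shown below. What is called first, only, known or untested is meant among the compounds shown, and "the series" means these compounds.

All compounds here were tested in a functional assay on MDA-MB-231 cells (Homo sapiens) for inhibition, read by MTT assay, with a stated time of 72 h; a lower number here means a stronger inhibitor, a higher number a weaker inhibitor. Compound 1, `CC(C)C[C@H](NC(=O)c1cc(Cl)ccc1OCCNC(=O)OC(C)(C)C)C(=O)Nc1ccc([N+](=O)[O-])cc1Cl`, carries a tert-butoxycarbonyl on an amine nitrogen. In this assay compound 1 gives > 10000 nM, which is a limit of the assay rather than a number. Compound 2, `CC(C)C[C@H](NC(=O)c1cc(Cl)ccc1OCCN)C(=O)Nc1ccc([N+](=O)[O-])cc1Cl`, differs from compound 1 in one place: hydrogen in place of tert-butoxycarbonyl on an amine nitrogen. In this assay compound 2 gives > 10000 nM, again a limit. The step between them, a step that the two limits leave unreadable from compound 1 to compound 2, cannot be sized because both values sit at the limit of > 10000 nM in this assay, at which 2 of the 3 values shown sit.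

Compound 3, `CC(C)[C@H](NC(=O)c1cc(Cl)ccc1OCCNC(=O)OC(C)(C)C)C(=O)Nc1ccc(F)c(F)c1`, is built on a different core; the difference between the two cores is not broken down here. In this assay, going by the values given here, compound 3 gives 3720 nM, the only actual number among the three measured compounds. Compound 4, `CC(C)[C@H](NC(=O)c1cc(Cl)ccc1OCCN)C(=O)Nc1ccc(F)c(F)c1`, has not yet been measured. It differs from compound 3 by hydrogen in place of tert-butoxycarbonyl on an amine nitrogen, the same change as that from compound 1 to compound 2, at a place described in the same words.

Among the compounds with values here, the one measured example of this change reads only as two limits, so it offers no size to lean on. Resting on compound 3 giving 3720 nM as a real number, the expected change is a 1.3-fold higher number from compound 3 to compound 4 (0.13 log units; within the scatter), a step kept deliberately modest in the absence of a readable precedent. Compound 4 is therefore estimated at 5000 nM, with a range from 1500 nM to 20000 nM, and a real chance that this assay again reports only a limit.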

Compound 4, half-maximal inhibitory concentration: > 10000 nM
Compound 4 gave a limit, no number; the forecaster's own chance of this, stated with the estimate: 35%; middle value at least 2.0-fold (0.30 log units) from the limit.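

In this assay, replacing the tert-butoxycarbonyl on the amine nitrogen of compound 3 with hydrogen gives an at least 2.6-fold higher number from compound 3 to compound 4 (0.42 log units; beyond the scatter), so on this core the step points to a weaker inhibitor and lies beyond the usual scatter. The same change on the core of compound 1 cannot be read, which means the new step does not contradict that earlier pair but gains no support from it either, and a single readable pair cannot establish that the change behaves alike on both cores. Compound 4 stands at a limit of the assay rather than a number, so the step has a lower bound but no known size, and the effect of the change cannot be compared between the two cores because the readings rest on one limit: the limit of > 10000 nM in this assay, at which 3 of the 4 values shown sit.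

The compounds shown leave open how other groups on this nitrogen would read, such as an acetyl amide, a methyl carbamate or a dimethylamine in place of the free amine, and whether a longer chain would behave like the 2-aminoethyl chain. Going by these compounds alone, they also leave open whether the tert-butoxycarbonyl group itself matters on the core of compound 1, where no pair gives a number.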